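A few compounds are considered here, and "the series" means these few. Any claim that something is new, unique, unknown or untested is made for them only; others in the source may bear on it.

Going by the values given here, compound 2 `CCC(CC)N(CCN(C)C(=O)CCC(=O)O)Cc1cccc(C(=O)Nc2sc3c(c2C(=O)c2cnn(Cc4ccccc4)c2)CCC(C)(C)C3)c1` gives 179 nM in an assay on isolated protein for inhibition of sodium-dependent phosphate transport protein 2B (Homo sapiens) (a lower number here means a stronger inhibitor, a higher number a weaker inhibitor), the only numerical value in the set so far. Compound 1 `CCC(CC)N(CCN(C)C(=O)CCC(=O)O)Cc1cccc(C(=O)Nc2sc3c(c2C(=O)c2cnn(-c4ccc(Cl)cc4)c2)CCN(C(C)=O)C3)c1` reaches the limit of this assay, > 1000 nM, which is not a number; this is the limit of > 1000 nM in this assay, at which 1 of the 2 values shown sits. Compound 3 `CCC(CC)N(CCN(C)C(=O)CCC(=O)O)Cc1cccc(C(=O)Nc2sc3c(c2C(=O)c2cnn(Cc4nnc[nH]4)c2)CCC(C)(C)C3)c1` carries 4H-1,2,4-triazol-3-yl in place of phenyl on a saturated chain carbon bound to an aromatic nitrogen relative to compound 2. Among the compounds with values here, no step between measured compounds is available, so the size of the coming step rests on the change alone. The step from compound 2 to compound 3 in this assay is expected at a 2.2-fold higher number from compound 2 to compound 3 (0.35 log units; beyond the scatter), a modest loss beyond the scatter. Compound 3 is estimated at 400 nM, with a range of 130 nM to 1200 nM.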

Compound 3, half-maximal inhibitory concentration: > 1000 nM
Compound 3: no number, only a limit; the forecaster's own chance of this, stated with the estimate: 25%; middle value at least 2.5-fold (0.39 log units) from the limit.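

In this assay, 4H-1,2,4-triazol-3-yl in place of phenyl on a saturated chain carbon bound to an aromatic nitrogen gives an at least 5.5-fold higher number from compound 2 to compound 3 (0.74 log units; beyond the scatter). This is the only one-place change shown, and it shows that this position does not accept the exchange without a loss beyond the scatter. Compound 3 sits at a limit and not at a number, so the step gives only a lower bound on the loss: the limit of > 1000 nM in this assay, at which 2 of the 3 values shown sit.

On these data alone, whether a pyridin-2-yl ring or a methyl group on the triazole nitrogen would hold the value of compound 2 stays open. So does the effect of a longer chain at this place.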